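Removing one methoxy from compound 2

This account rests on a few compounds, and the source may have more. Where it says the series, first, only, none or still open, it means among the compounds named here.

In a functional assay on MCF7 cells (Homo sapiens) for cytotoxicity, read by MTT assay, with a stated time of 72 h (a higher number here means a weaker inhibitor, a lower number a stronger inhibitor), compound 1 (`COc1ccc(/C=C/c2cc(C)no2)cc1OC`) reads > 100000 nM, which is a limit of the assay and not a number. For the measured compounds named here, compound 2 (`COc1ccc(/C=C/C(=O)CC(C)=O)cc1OC`) gives 10600 nM, the only actual number so far. Going by the values given here, the single measured step, an at least 9.4-fold lower number from compound 1 to compound 2 (0.97 log units; beyond the scatter), exchanges 3-methyl-1,2-oxazol-5-yl for (2-oxopropyl)carbonyl on the chain and leaves both methoxy groups untouched.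

Compound 3 (`COc1ccc(/C=C/C(=O)CC(C)=O)cc1`) differs from compound 2 as follows: hydrogen in place of methoxy on an aromatic carbon. This puts hydrogen in place of methoxy on an aromatic carbon, ortho to a methoxy group. The measured step therefore sets no size for this change, and the keto chain of compound 2 is retained. In this assay, no shift beyond the scatter is expected, so the estimated move is a 1.2-fold higher number from compound 2 to compound 3 (0.09 log units; within the scatter). For compound 3 the expected value is 13000 nM, with an estimated range of 5000 nM to 35000 nM.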

Compound 3, half-maximal inhibitory concentration: 15800 nM
For compound 3 the middle estimate is 1.2-fold (0.08 log units) below the measured one; the range from low to high includes it.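

Hydrogen in place of methoxy on an aromatic carbon, ortho to a methoxy group, gives a 1.5-fold higher number from compound 2 to compound 3 (0.17 log units; within the scatter) in this assay, so this position can lose its methoxy without a change that the assay separates from the scatter. The earlier step touched only the chain, and this one shows that the keto chain compounds do not depend on having both methoxy groups to give a measurable number. Only compound 1 sits at a limit, which is not a number, whereas this step joins two measured values and can be sized: the limit of > 100000 nM in this assay, at which 1 of the 3 values shown sits.

On these data alone, whether an amine, a hydroxyl or a longer alkoxy chain at this position would read differently from hydrogen and methoxy stays open, as does the loss of the remaining methoxy. Also open, as far as these compounds go, is whether the same exchange would read alike with 3-methyl-1,2-oxazol-5-yl on the chain.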